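The source may report more compounds than this note shows. Statements on the series, on what has been measured and on what is new or still open speak of the compounds shown alone.

Measured so far in an ADME assay on MT4 cells (Homo sapiens) for cytotoxicity, read by MTT assay; a lower number here means that less compound is tolerated, a higher number that more compound is tolerated:
- Compound 1 `CC(=O)CSc1nc(Cc2c(F)cccc2F)cc(=O)[nH]1`: > 81000 nM, which is a limit and not a number
- Compound 2 `COc1ccc(CSc2nc(Cc3c(Cl)cccc3Cl)c(C)c(=O)[nH]2)cc1`: 32000 nM

Going by the values given here, compound 2 holds the only real number so far in this assay, at 32000 nM, so there is no ranking to read from it. Among the compounds with values here, its one neighbour offers just a limit, as the limit of > 81000 nM in this assay, at which 1 of the 2 values shown sits, records.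

The next compound, compound 3 `Cc1c(Cc2c(Cl)cccc2Cl)nc(SCC(=O)c2ccc(F)cc2)[nH]c1=O`, has not yet been measured. It differs from compound 2 in one place: (4-fluorophenyl)carbonyl in place of 4-methoxyphenyl on a saturated chain carbon bound to a sulfur. Here (4-fluorophenyl)carbonyl stands in place of 4-methoxyphenyl on a saturated chain carbon bound to a sulfur.

Within the data shown here, no measured pair shows what such a swap does, so only a cautious expectation is possible. The estimated change, a 1.2-fold higher number from compound 2 to compound 3 (0.07 log units; within the scatter), is expected to stay within the usual scatter. For compound 3 the expected value is 38000 nM, with an estimated range from 12000 nM to 100000 nM.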

Compound 3, half-maximal cytotoxic concentration: > 57000 nM
Compound 3: a limit, no number; the forecaster's own chance of this, stated with the estimate: 35%; middle value at least 1.5-fold (0.17 log units) away from the limit.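

In this assay compound 3 ends at a limit of the assay and not at a number: the limit of > 57000 nM in this assay, at which 1 of the 3 values shown sits. Going by these compounds alone, this gives the first reading of a change on a saturated chain carbon bound to a sulfur, with (4-fluorophenyl)carbonyl in place of 4-methoxyphenyl, and the result is an at least 1.7-fold higher number from compound 2 to compound 3 (0.25 log units; that floor lies within the scatter). Since only a floor can be read, the step shows that this exchange is compatible with a limit in this assay, but it does not give the real size of the change.

The swap brings in a carbonyl and a fluorine together, so the share of each in this step stays unresolved. Also open, from the compounds shown here alone, is what a plain 4-fluorophenyl without the carbonyl, a carboxylic acid or an amine would give on this same carbon.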